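The source may hold more compounds than are shown below. What is called first, only, known or untested is meant among the compounds shown, and "the series" means these compounds.

Measured in an ADME assay on MRC5 cells (Homo sapiens) for cytotoxicity, read by MTT assay, with a stated time of 24 h (a higher number here means that more compound is tolerated, a lower number that less compound is tolerated), so far:
- Compound 1 `CC1(C)[C@H]2CC[C@]1(C)N(Cc1cn(-c3ccccc3C#N)nn1)C(=O)C2` gives 23300 nM
- Compound 2 `CC1(C)[C@H]2CC[C@]1(C)N(Cc1cn(-c3ccccc3Cl)nn1)C(=O)C2` gives 4130 nM

Compound 2 has the lower of the two numbers, so less of it is tolerated. Compound 3 `CC1(C)[C@H]2CC[C@]1(C)N(Cc1cn(-c3cccc(Cl)c3)nn1)C(=O)C2` has the same atoms joined differently, with 3-chlorophenyl in place of 2-chlorophenyl on an aromatic nitrogen. For the measured compounds named here, the only measured step, a 5.6-fold lower number from compound 1 to compound 2 (0.75 log units; beyond the scatter), exchanges one group for a different one and shifts no chlorine, so it is a loose guide to size. A small rise within the scatter is therefore expected, an estimated 1.5-fold higher number from compound 2 to compound 3 (0.16 log units; within the scatter) in this assay here. For compound 3 the expected value is 6000 nM, with an estimated range from 2000 nM to 18000 nM overall.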

Compound 3, half-maximal cytotoxic concentration: 8840 nM
For compound 3 the middle estimate is 1.5-fold (0.17 log units) below the measured one; measured number inside the range.
By their numbers in this assay, from the lowest: compound 2; then compound 3; then compound 1.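

With the same atoms and only the chlorine moved, 3-chlorophenyl in place of 2-chlorophenyl gives a 2.1-fold higher number from compound 2 to compound 3 (0.33 log units; beyond the scatter) in this assay and so shows that the chlorine's place on this ring alone changes the result. Even so, the chlorine compounds stay apart from the nitrile, with a 2.6-fold lower number from compound 1 to compound 3 (0.42 log units; beyond the scatter) as the remaining gap, which leaves compound 1 the most tolerated of the three. No measurement shown explains either shift.

Still open, from the compounds shown here alone, is whether an amine or a methoxy group in place of the chlorine on the 3-chlorophenyl would raise the number further.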